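The source may report more compounds than this note shows. Statements on the series, on what has been measured and on what is new or still open speak of the compounds shown alone.

Measured compounds:
Compound 1, `NC(=O)c1ccccc1Cn1cc(-c2ccc3cn[nH]c3c2)ccc1=O`: 340 nM
Compound 2, `O=c1ccc(-c2ccc3cn[nH]c3c2)cn1Cc1ccccc1Cl`: 78 nM

Going by the values given here, in an assay for inhibition of MAP kinase-interacting serine/threonine-protein kinase 2 (Homo sapiens), read by luminescence and ADP-Glo, with a stated time of 2 h (on this read-out lower numbers stand for stronger inhibition and higher numbers for weaker inhibition), compound 2 gives 78 nM, the lowest of the two numbers measured so far; its only neighbour is compound 1, which gives 340 nM, and the step between them is a 4.4-fold lower number from compound 1 to compound 2 (0.64 log units; beyond the scatter). Compound 3, `O=c1ccc(-c2ccc3cn[nH]c3c2)cn1Cc1ccc(Cl)c(Cl)c1`, has not yet been measured. It differs from compound 2 by 3,4-dichlorophenyl in place of 2-chlorophenyl on a saturated chain carbon bound to an aromatic nitrogen. Among the compounds with values here, the one measured step, from compound 1 to compound 2, exchanged one group for another on the ring that carries the chlorine, but it does not test the change from 2-chlorophenyl to 3,4-dichlorophenyl, so it bears on this step only loosely. Without a direct precedent, the expectation is a step of modest size or none beyond the scatter, leaning toward a somewhat higher number. Compound 3 is expected to give 120 nM in this assay, with a range from 40 nM to 400 nM. That estimate means a 1.5-fold higher number from compound 2 to compound 3 (0.19 log units; within the scatter).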

Compound 3, half-maximal inhibitory concentration: 97 nM
Estimate against measurement, compound 3: 1.2-fold (0.09 log units) above, within the range that was stated.
By their numbers in this assay, from the lowest: compounds 2 and 3 (each within the scatter of the next); then compound 1.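

In this assay, replacing 2-chlorophenyl with 3,4-dichlorophenyl on a saturated chain carbon bound to an aromatic nitrogen gives a result that cannot be told apart from no change at all (a 1.2-fold higher number from compound 2 to compound 3 (0.09 log units; within the scatter)). The earlier step (a 4.4-fold lower number from compound 1 to compound 2 (0.64 log units; beyond the scatter)) showed that swapping carbamoyl for chloro on this ring matters, whereas this one shows that a second chlorine, together with a different chlorine pattern on the ring, leaves the number within the scatter. Nothing measured here offers an explanation for this result.

The compounds shown leave open whether any chlorine is needed, since a plain phenyl ring does not appear among them. They also leave open how this position would respond to a methoxy group, an amine or a carboxylic acid on the ring, or to a longer chain in place of the saturated chain carbon.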